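This account rests on a few compounds, and the source may have more. Where it says the series, first, only, none or still open, it means among the compounds named here.

Three compounds with the same core differ only in the group on a carbonyl carbon. In a functional assay on U2OS cells (Homo sapiens) for antiproliferative activity, read by MTT assay, with a stated time of 72 h (a lower number here means a stronger inhibitor, a higher number a weaker inhibitor), compound 3 `CCCC(=O)Nc1nc2ccc(NC(=O)CSc3cccc(O)c3)cc2s1`, which carries propyl there, gives 10100 nM. Compound 2 `O=C(CSc1cccc(O)c1)Nc1ccc2nc(NC(=O)c3ccc(F)cc3)sc2c1`, which carries 4-fluorophenyl, gives 5120 nM. The step between them is a 2.0-fold higher number from compound 2 to compound 3 (0.30 log units; within the scatter), so the two cannot be told apart. Compound 1 `O=C(CSc1cccc(O)c1)Nc1ccc2nc(NC(=O)c3ccccc3)sc2c1`, which carries phenyl, gives only a limit of the assay, > 100000 nM.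

Compound 4 `O=C(CSc1cccc(O)c1)Nc1ccc2nc(NC(=O)c3ccc4ccccc4c3)sc2c1` changes compound 3 as follows: naphthalen-2-yl in place of propyl on a carbonyl carbon. In words, naphthalen-2-yl takes the place of propyl on a carbonyl carbon.

The measured steps at this same place give mixed guidance. Swapping hydrogen for fluoro on the phenyl group gives an at least 19-fold lower number from compound 1 to compound 2 (1.29 log units; beyond the scatter), a large change from a small edit. Replacing phenyl with propyl gives an at least 9.9-fold lower number from compound 1 to compound 3 (0.99 log units; beyond the scatter). On these data alone, both steps start from a limit, so their true sizes are unknown. Compound 2 and compound 3 show that an aromatic group and a short chain can give matching numbers, whereas compound 1 shows that an aromatic group can also sit far out at the limit.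

These steps point in no clear direction, so no step beyond the scatter is expected, though a much weaker result remains possible. The expected change is a 1.3-fold lower number from compound 3 to compound 4 (0.10 log units; within the scatter). For compound 4 the estimated value is 8000 nM, with an expected range of 2000 nM to 40000 nM.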

Compound 4, half-maximal inhibitory concentration: 1770 nM
The estimate for compound 4 lay 4.5-fold (0.66 log units) above the measured number; measured number outside the range, below it.
By their numbers in this assay, from the lowest: compound 4; then compounds 2 and 3 (each within the scatter of the next). At a limit, above all of these: compound 1.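

In this assay, for the compounds shown here, naphthalen-2-yl is the first group at this place that separates clearly from the others: the result is a 5.7-fold lower number from compound 3 to compound 4 (0.76 log units; beyond the scatter), and against the aromatic group of compound 2 it is a 2.9-fold lower number from compound 2 to compound 4 (0.46 log units; beyond the scatter). Going by these compounds alone, compound 2 and compound 3 could not be told apart, so compound 4 is the first sign that the group on this carbonyl carbon can move the number beyond the scatter in a favourable direction, and it is now the strongest of the four. Size alone does not explain the series, though, since compound 1 carries phenyl, larger than propyl, and goes against any simple trend from small to large; the step of an at least 56-fold lower number from compound 1 to compound 4 (1.75 log units; beyond the scatter) starts from a limit, so its true size is unknown: the limit of > 100000 nM in this assay, at which 1 of the 4 values shown sits.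

The compounds shown leave open whether the two aromatic rings of naphthalen-2-yl matter as such, or whether a single ring with a larger substituent, such as 4-chlorophenyl, would serve as well. They also leave open how a longer chain such as hexyl, or a group carrying an amine, would behave at this place.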